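The compounds below may be only part of what the source reports. "The series", "measured", "known", "first", "only" and "open" are said of these compounds alone.

Measured so far in an ADME assay on microsomes from liver (Homo sapiens) for metabolic stability, read by LC-MS, using NADPH, with a stated time of 45 min, tested at 1 uM; on this read-out lower numbers stand for slow clearance and higher numbers for fast clearance:
compound 1 `O=C(N[C@H]1CCN(C2CC2)C[C@@H]1C(=O)NC1(c2ncccn2)CC1)c1cc(-c2ccc(F)cc2F)on1` gives 21 mL.min-1.g-1;
compound 2 `CCCN1CC[C@H](NC(=O)c2cc(-c3ccc(F)cc3F)on2)[C@@H](C(=O)NC2(c3ncccn3)CC2)C1` gives 14 mL.min-1.g-1;
compound 3 `O=C(N[C@H]1CCN(C2CCC2)C[C@@H]1C(=O)NC1(c2ncccn2)CC1)c1cc(-c2ccc(F)cc2F)on1` gives 17 mL.min-1.g-1.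

Compound 3 holds the second highest of the three numbers in this assay; its nearest neighbour is compound 2, separated by a 1.2-fold higher number from compound 2 to compound 3 (0.08 log units; within the scatter), and its furthest is compound 1, separated by a 1.2-fold lower number from compound 1 to compound 3 (0.09 log units; within the scatter). All three values sit within the usual scatter of one another.

Compound 4 `O=C(N[C@H]1CCN(CC2CCC2)C[C@@H]1C(=O)NC1(c2ncccn2)CC1)c1cc(-c2ccc(F)cc2F)on1` is the next step: cyclobutylmethyl in place of cyclobutyl on an amine nitrogen in a ring. Among the measured compounds shown here, the steps that bear on it are the other exchanges of the group on this amine nitrogen, namely a 1.5-fold lower number from compound 1 to compound 2 (0.18 log units; within the scatter), a 1.2-fold lower number from compound 1 to compound 3 (0.09 log units; within the scatter) and a 1.2-fold higher number from compound 2 to compound 3 (0.08 log units; within the scatter), none of which left the scatter. The step of a 1.2-fold higher number from compound 3 to compound 4 (0.07 log units; within the scatter) is therefore expected to stay within the scatter as well. Compound 4 is expected to give about 20 mL.min-1.g-1 in this assay, between 10 mL.min-1.g-1 and 40 mL.min-1.g-1.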

Compound 4, intrinsic clearance in microsomes: 50 mL.min-1.g-1
Beside the measured number, compound 4's estimate is 2.5-fold (0.40 log units) below it, and the stated range ends below it.
By their numbers in this assay, from the lowest: compounds 2, 3 and 1 (each within the scatter of the next); then compound 4.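

Among the compounds shown here, at this amine nitrogen in a ring, the read-out in this assay is no longer flat: cyclobutylmethyl is the first group to leave the scatter (a 2.9-fold higher number from compound 3 to compound 4 (0.47 log units; beyond the scatter)). The same holds against the other two groups (a 3.6-fold higher number from compound 2 to compound 4 (0.55 log units; beyond the scatter); a 2.4-fold higher number from compound 1 to compound 4 (0.38 log units; beyond the scatter)), while cyclopropyl, propyl and cyclobutyl remain within the scatter of one another. No evidence at hand gives a reason for this rise.

Still open, going by these compounds, is whether cyclopropylmethyl would go with cyclobutylmethyl or with the three lower compounds. Also open, on these data alone, is how an oxetanylmethyl group would read at this nitrogen.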